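Pyrazoline series: inhibition of protein kinase C zeta

The source may hold more compounds than are shown below. What is called first, only, known or untested is meant among the compounds shown, and "the series" means these compounds.

Measured compounds:
compound 1, `CC(C)c1ccc(N2N=C(C(C)(C)C)CC2c2ccc(O)cc2)cc1`, 54.9%
compound 2, `CC(C)(C)C1=NN(c2ccc(Cl)cc2Cl)C(c2ccc(O)cc2)C1`, 71%

Two members of the series have been read in an assay on isolated protein for inhibition of protein kinase C zeta type (Homo sapiens), with a stated time of 4 min, tested at 62.5 uM; a lower number here means less inhibition, a higher number more inhibition at the concentration tested (going by the name of the read-out). Compound 1 gives 54.9% and compound 2 gives 71%. Compound 2 stands highest of the two numbers; its nearest neighbour is compound 1, lower by a gap that lies beyond the scatter. Among the measured compounds shown here, the two differ in more than one place, so no single step between them is recorded; the two values are all that can be said of the pair.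

The next compound is compound 3, `CC(C)(C)C1=NN(c2ccc(O)cc2)C(c2ccc(O)cc2)C1`. It differs from compound 2 in a single place: 4-hydroxyphenyl in place of 2,4-dichlorophenyl on an amine nitrogen in a ring. The group that leaves carries no hydrogen-bond donor or acceptor, the group that enters carries one of each, on an amine nitrogen in a ring.

For the measured compounds named here, no measured step covers such a change, so the expectation rests on the two values alone. A decrease beyond the scatter is expected in this assay, of the size a number 16 percentage points lower from compound 2 to compound 3 (beyond the scatter). Compound 3 is estimated at 55%, within a range from 35% to 75%.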

Compound 3, a percentage reported as inhibition, at one concentration (the size of the read-out at that concentration, not a potency): 40.9%
Compound 3: middle estimate off by 14.1 percentage points, on the high side; measured number inside the range.
By their numbers in this assay, from the lowest: compound 3; then compound 1; then compound 2.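

Working notes on the amine nitrogen in a ring: in this assay, 4-hydroxyphenyl in place of 2,4-dichlorophenyl gives a number 30.1 percentage points lower from compound 2 to compound 3 (beyond the scatter), the first single-place step read at this position, and it shows that the aryl group there is not neutral for inhibition at the concentration tested. The second step, hydroxy in place of isopropyl on an aromatic carbon, gives a number 14 percentage points lower from compound 1 to compound 3 (beyond the scatter), so both single-place steps into compound 3 run downward, beyond the scatter, and in this set of three the 4-hydroxyphenyl group goes with the lowest number. Nothing at hand bears on why the number falls with either change.

On these data alone, the step from 2,4-dichlorophenyl to 4-hydroxyphenyl bundles the loss of both chlorines with the gain of the hydroxy group, so the share of each in the fall stays open. A 4-chlorophenyl, 4-methoxyphenyl or 4-aminophenyl group at the same position would separate these contributions, and a plain phenyl group there would give a reference for all of them.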